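This account rests on a few compounds, and the source may have more. Where it says the series, first, only, none or still open, it means among the compounds named here.

Measured compounds in a functional assay on MOLT-4 cells (Homo sapiens), with a stated time of 72 h; on this read-out higher numbers stand for weaker inhibition and lower numbers for stronger inhibition: compound 1 `O=C1Nc2ccc(Cl)cc2/C1=N/NC(=S)Nc1ccc(Cl)cc1` gives 64000 nM; compound 2 `Cc1ccc(NC(=S)N/N=C2\C(=O)Nc3ccc(F)cc32)cc1` gives 3000 nM; compound 3 `O=C1Nc2ccc(F)cc2/C1=N/NC(=S)Nc1ccc(Cl)cc1` gives 14000 nM.

Compound 3 stands second highest of the three, between compound 1 and compound 2. Both known steps swap one aromatic substituent: a 4.6-fold lower number from compound 1 to compound 3 (0.66 log units; beyond the scatter) and a 4.7-fold higher number from compound 2 to compound 3 (0.67 log units; beyond the scatter), each modest and beyond the scatter.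

Compound 4 `O=C1/C(=N\NC(=S)Nc2ccc(Cl)cc2)c2cc(F)ccc2N1Cc1ccc(F)cc1` differs from compound 3 by 4-fluorobenzyl in place of hydrogen on an amide-type nitrogen in a ring. Among the measured compounds shown here, neither measured step touches the amide-type nitrogen, so no step bears on this change and the data alone give no direction. The working expectation for compound 4 in this assay is therefore a step within or near the scatter, wording it as a 1.4-fold lower number from compound 3 to compound 4 (0.15 log units; within the scatter). Compound 4 is thus estimated at 10000 nM, with a range of 2000 nM to 50000 nM.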

Compound 4, half-maximal inhibitory concentration: 47000 nM
Compound 4: middle estimate off by 4.7-fold (0.67 log units), on the low side, within the range that was stated.
By their numbers in this assay, from the lowest: compound 2; then compound 3; then compounds 4 and 1 (each within the scatter of the next).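

In this assay, among the compounds shown here, the amide-type nitrogen in the ring responds to substitution, a position the earlier compounds left untouched: 4-fluorobenzyl in place of hydrogen gives a 3.4-fold higher number from compound 3 to compound 4 (0.53 log units; beyond the scatter). This modest step runs towards weaker inhibition, yet it does not abolish activity on this read-out. No measurement shown gives a reason for the shift.

Still open, from the compounds shown here alone, is whether the step belongs to 4-fluorobenzyl specifically or to any group on this nitrogen. An unsubstituted benzyl or an aminoethyl chain at the same place would separate the two.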